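The source may hold more compounds than are shown below. What is called first, only, known or untested is meant among the compounds shown, and "the series" means these compounds.

Measured so far in a functional assay on A549 cells (Homo sapiens) for antiproliferative activity, read by MTT assay, with a stated time of 48 h; on this read-out higher numbers stand for weaker inhibition and lower numbers for stronger inhibition:
- compound 1 `Cn1cc(-c2cnc3ccc(NC(=O)c4ccc(F)cc4)nc3c2)cn1`: > 50000 nM (a limit)
- compound 2 `COc1ccc(C(=O)Nc2ccc3ncc(-c4cnn(C)c4)cc3n2)cc1`: 6400 nM
- compound 3 `Cn1cc(-c2cnc3ccc(NC(=O)c4cccnc4)nc3c2)cn1`: > 50000 nM (a limit)

Compound 3 has no number, only the limit > 50000 nM. It shares this position with one other compound: the limit of > 50000 nM in this assay, at which 2 of the 3 values shown sit.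

Compound 4 `Cn1cc(-c2cnc3ccc(NS(=O)(=O)c4cccs4)nc3c2)cn1` has (thiophen-2-yl)sulfonyl in place of (pyridin-3-yl)carbonyl on a nitrogen on an aromatic ring.

The nearest measured changes are at this same nitrogen: an at least 7.8-fold lower number from compound 1 to compound 2 (0.89 log units; beyond the scatter), an at least 7.8-fold higher number from compound 2 to compound 3 (0.89 log units; beyond the scatter) and a step that the two limits leave unreadable from compound 1 to compound 3. The first two lie beyond the scatter, so exchanges here can matter. None of them introduces a sulfonyl or a thiophene, so direction remains uncertain. A modest gain is expected: an at least 2.0-fold lower number from compound 3 to compound 4 (0.30 log units; that floor lies within the scatter). Compound 4 is estimated at 25000 nM, with an expected range of 6000 nM to 80000 nM.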

Compound 4, half-maximal inhibitory concentration: 39500 nM
Compound 4: middle estimate off by 1.6-fold (0.20 log units), on the low side; measured number inside the range.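

Replacing the (pyridin-3-yl)carbonyl on this nitrogen with (thiophen-2-yl)sulfonyl gives compound 4 a readable number in this assay, so this position tolerates a sulfonyl as well as a carbonyl link: an at least 1.2-fold lower number from compound 3 to compound 4 (0.10 log units; that floor lies within the scatter). Compound 3 has only a limit, > 50000 nM, and the floor of the step lies within the scatter. The true size stays unreadable, since compound 3 sits at the shared limit: the limit of > 50000 nM in this assay, at which 2 of the 4 values shown sit.

Sulfonyl and thiophene change together in compound 4, so their contributions remain unseparated. A (4-methoxyphenyl)sulfonyl group on this nitrogen would bear on that question.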